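A few compounds are considered here, and "the series" means these few. Any claim that something is new, unique, unknown or untested is made for them only; others in the source may bear on it.

Measured so far in a functional assay on RS4-11 cells (Homo sapiens) for inhibition, read by CCK-8 assay, with a stated time of 48 h, tested at 20 uM; on this read-out lower numbers stand for less inhibition of growth and higher numbers for more inhibition of growth at the one concentration tested:
compound 1 `COc1ccc(Cc2nnc(NC(=O)/C(C#N)=C/c3ccccc3OS(=O)(=O)c3ccc(C)cc3)s2)cc1`: 70%
compound 2 `COc1ccc(Cc2nnc(NC(=O)/C(C#N)=C/c3ccccc3OS(=O)(=O)c3ccc([N+](=O)[O-])cc3)s2)cc1`: 70%
compound 3 `COc1ccc(Cc2nnc(NC(=O)/C(C#N)=C/c3ccccc3OS(=O)(=O)c3ccccc3[N+](=O)[O-])s2)cc1`: 68%

The three compounds form a single group in this assay. The numbers show a number 2 percentage points lower from compound 1 to compound 3 (within the scatter) and a number 2 percentage points lower from compound 2 to compound 3 (within the scatter). Compound 3 therefore has no separate place in the series and lies within the scatter of both other compounds.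

The next compound is compound 4 `COc1ccc(Cc2nnc(NC(=O)/C(C#N)=C/c3ccccc3OS(=O)(=O)c3ccc(F)cc3)s2)cc1`. It carries 4-fluorophenyl in place of 2-nitrophenyl on a sulfonyl sulfur. All three measured steps bear on this change, as each alters the same aromatic group on the sulfonyl sulfur. Nitro in place of methyl on an aromatic carbon gave no change at the digits printed from compound 1 to compound 2 (within the scatter). 2-Nitrophenyl in place of 4-methylphenyl gave a number 2 percentage points lower from compound 1 to compound 3 (within the scatter), and 2-nitrophenyl in place of 4-nitrophenyl gave a number 2 percentage points lower from compound 2 to compound 3 (within the scatter). None of the three steps goes beyond the scatter. Among the measured compounds shown here, no compound with a fluorine on this ring has been measured, however, so the comparison is indirect. No step beyond the scatter is expected here, in either direction. The expected step is a number 1 percentage points higher from compound 3 to compound 4 (within the scatter). Compound 4 is estimated at 69%, with an expected range from 57% to 80%.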

Compound 4, percent growth inhibition at one concentration: 80%
Beside the measured number, compound 4's estimate is 11 percentage points below it; the range from low to high includes it.
By their numbers in this assay, from the lowest: compounds 3, 1, 2 and 4 (each within the scatter of the next, the first and the last beyond it).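

Among the compounds shown here, on the aromatic group held by the sulfonyl sulfur, this assay now shows the first step at this position that goes beyond the scatter: 4-fluorophenyl in place of 2-nitrophenyl gives a number 12 percentage points higher from compound 3 to compound 4 (beyond the scatter) and this step is modest. The other two comparisons stay within the scatter, with fluoro in place of nitro giving a number 10 percentage points higher from compound 2 to compound 4 (within the scatter) and fluoro in place of methyl giving a number 10 percentage points higher from compound 1 to compound 4 (within the scatter) so the fluorine separates compound 4 only from compound 3, and not from compound 1 or compound 2. Nothing available on these compounds accounts for the step.

The compounds shown leave open whether other groups on this ring, such as a chlorine, an amine or a carboxylic acid, would fall with compound 3 or with compound 4, and whether a methyl group directly on the sulfonyl sulfur would keep the growth inhibition seen with these aromatic groups. With a single concentration behind each number, they also leave open how compound 3 and compound 4 would compare across a full range of concentrations.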